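Hydroxy to Methoxy on the Aryl-Oxadiazole Arm

The compounds below may be only part of what the source reports. "The series", "measured", "known", "first", "only" and "open" are said of these compounds alone.

Measured compounds in a physicochemical assay for lipophilicity, measured as octanol-water partition; a lower number here means a more polar compound, a higher number a more lipophilic compound:
compound 1 `Cc1c(NCc2nnc(-c3ccccc3O)o2)c(=O)n(-c2ccccc2)n1C`: 1.71
compound 2 `Cc1c(NCc2nnc(-c3ccncc3)o2)c(=O)n(-c2ccccc2)n1C`: 0.8
compound 3 `Cc1ccccc1-c1nnc(CNc2c(C)n(C)n(-c3ccccc3)c2=O)o1`: 2.38

Compound 1 stands second highest of the three numbers. Its nearest neighbour is compound 3, reached by a number 0.67 log units higher from compound 1 to compound 3 (beyond the scatter). Further away is compound 2, reached by a number 0.91 log units lower from compound 1 to compound 2 (beyond the scatter). Between those two, a number 1.58 log units higher from compound 2 to compound 3 (beyond the scatter) spans the whole range of the set.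

Compound 4 `COc1ccc(-c2nnc(CNc3c(C)n(C)n(-c4ccccc4)c3=O)o2)cc1` has not yet been measured in this assay. Compared with compound 1, the change is 4-methoxyphenyl in place of 2-hydroxyphenyl on an aromatic carbon. Among the compounds with values here, one measured step bears on it most directly: the replacement of hydroxy by methyl on the same aromatic carbon, which gave a number 0.67 log units higher from compound 1 to compound 3 (beyond the scatter), a modest rise beyond the scatter. The methoxy group of compound 4 likewise carries no hydrogen-bond donor, and the ring that enters is a six-membered aromatic ring of carbon only, as in compound 3. Within the data shown here, no measured step shows a methoxy group itself. On that basis a modest rise beyond the scatter is expected, estimated as a number 0.49 log units higher from compound 1 to compound 4 (beyond the scatter). Compound 4 is therefore expected to give about 2.2, with a likely range from 1.8 to 2.6.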

Compound 4, partition coefficient: 2.07
Compound 4: the middle estimate sits 0.13 log units above what was measured; the measured number falls inside the stated range.
By their numbers in this assay, from the lowest: compound 2; then compound 1; then compound 4; then compound 3.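

Within the data shown here, with compound 4, a methoxy group enters this position for the first time, and in this assay the swap of 2-hydroxyphenyl for 4-methoxyphenyl still gives a rise, a number 0.36 log units higher from compound 1 to compound 4 (beyond the scatter), which is smaller than the rise seen with 2-methylphenyl, a number 0.67 log units higher from compound 1 to compound 3 (beyond the scatter). The two arms without a hydrogen-bond donor therefore do not share one number, as the direct comparison shows, a number 0.31 log units lower from compound 3 to compound 4 (beyond the scatter), so removing the donor of compound 1 does not by itself fix the result at this position. The pyridin-4-yl arm remains well apart from the new compound, a number 1.27 log units higher from compound 2 to compound 4 (beyond the scatter), a large step that leaves all three arms with a six-membered aromatic ring of carbon only above compound 2 in this set. Nothing available explains why these steps differ in size. As far as these compounds go, what a phenyl ring bearing an amino group or a carboxylic acid would give here stays open, as does how much of the step from compound 1 belongs to the change of group and how much to where that group sits on the phenyl ring.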